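Furan-to-thiophene exchange across two nucleoside cores

The source may report more compounds than this note shows. Statements on the series, on what has been measured and on what is new or still open speak of the compounds shown alone.

Compound 1 `Cc1nc(N)c2c(-c3cccs3)cn([C@@H]3O[C@H](CO)[C@@H](O)[C@H]3O)c2n1`. In an ADME assay on MRC5 cells (Homo sapiens), read by MTT assay, with a stated time of 72 h (on this read-out higher numbers stand for weaker inhibition and lower numbers for stronger inhibition), compound 1 gives > 100000 nM, which is a limit of the assay and not a number.
Compound 2 `Cc1nc(N)c2c(-c3ccco3)cn([C@@H]3O[C@H](CO)[C@@H](O)[C@H]3O)c2n1`. In this assay compound 2 gives > 100000 nM, again a limit of the assay rather than a number.
Compound 3 `Nc1nc2c(c(-c3ccco3)cn2[C@@H]2O[C@H](CO)[C@@H](O)[C@H]2O)c(=O)[nH]1`. In this assay compound 3 gives > 100000 nM, also a limit of the assay.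

Compounds 1 and 2 share one core and differ only in thiophen-2-yl in place of furan-2-yl on an aromatic carbon. The step that the two limits leave unreadable from compound 2 to compound 1 cannot be read, since both ends rest at the limit of > 100000 nM in this assay, at which 3 of the 3 values shown sit. Compound 3 carries a different core; the difference between the core of compound 3 and the core of compound 2 is not broken down here.

Compound 4 `Nc1nc2c(c(-c3cccs3)cn2[C@@H]2O[C@H](CO)[C@@H](O)[C@H]2O)c(=O)[nH]1` has not yet been measured. Going by the values given here, it differs from compound 3 in thiophen-2-yl in place of furan-2-yl on an aromatic carbon, which is the same change as the one between compound 2 and compound 1, made at the same place on the other core. Because every measured compound sits at the limit of > 100000 nM in this assay, at which 3 of the 3 values shown sit, the step from compound 3 to compound 4 in this assay is expected to be a step that the limit leaves unreadable from compound 3 to compound 4, and this expectation rests only on the fact that the change gave no readable movement in the measured pair. Compound 4 is therefore expected to give about 200000 nM, within a range from 100000 nM to 500000 nM, and most probably the assay will again report only a limit for compound 4.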

Compound 4, half-maximal inhibitory concentration: > 100000 nM
Compound 4 was reported as a limit; the forecaster's own chance of this, stated with the estimate: 90%; the middle value does not contradict the limit.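

In this assay compound 4 gives > 100000 nM, which is a limit of the assay and not a number. Compound 3 also rests at a limit, so no size can be read for the step between compound 3 and compound 4, and no new step emerges: the limit of > 100000 nM in this assay, at which 4 of the 4 values shown sit.

The compounds shown leave open whether thiophen-2-yl in place of furan-2-yl makes any difference on either core in this assay.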